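Swapping cyclopentyl for isopropyl on the shared core

This account rests on a few compounds, and the source may have more. Where it says the series, first, only, none or still open, it means among the compounds named here.

Compound 2 `COc1cc(C(=O)NC2CCN(C)CC2)ccc1Nc1ncc2c(n1)N(C1CCCC1)[C@H](C)C(=O)N2C` has the lowest number of the three measured compounds in an assay on isolated protein for inhibition of serine/threonine-protein kinase PLK1 (Homo sapiens), read by Z'-LYTE; a lower number here means a stronger inhibitor, a higher number a weaker inhibitor: compound 2 gives 1.1 nM. Compound 1 `CC[C@@H]1C(=O)N(C)c2cnc(Nc3ccc(C(=O)NC4CCN(C)CC4)cc3OC)nc2N1C(C)C` gives 4 nM, and compound 3 `COc1cc(C(=O)NC2CCN(C)CC2)ccc1Nc1ncc2c(n1)N(C1CCCC1)[C@@H](C)C(=O)N2C` gives 8.7 nM. Within the data shown here, the only measured single-point step is a 7.9-fold higher number from compound 2 to compound 3 (0.90 log units; beyond the scatter), and it rests on (the fact that compounds 2 and 3 differ only in the configuration as drawn). Compound 4 `COc1cc(C(=O)NC2CCN(C)CC2)ccc1Nc1ncc2c(n1)N(C(C)C)[C@H](C)C(=O)N2C` differs from compound 2 by isopropyl in place of cyclopentyl on a nitrogen on an aromatic ring in a ring. Among the measured compounds shown here, no measured step changes this group alone; compound 1 carries the same isopropyl but also a different chain at the stereocentre, so its value shows only that an isopropyl-bearing analogue stays potent. A small step, if any, is therefore expected, a 1.8-fold higher number from compound 2 to compound 4 (0.26 log units; within the scatter). Compound 4 is expected to give 2 nM, within a range from 0.7 nM to 6 nM.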

Compound 4, half-maximal inhibitory concentration: 25.2 nM
For compound 4 the middle estimate is 13-fold (1.10 log units) below the measured one; the measured number lies above the stated range.
By their numbers in this assay, from the lowest: compound 2; then compound 1; then compound 3; then compound 4.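

In this assay, among these compounds, the group on this nitrogen matters far more than the earlier compounds could show: the change from cyclopentyl to isopropyl gives a 23-fold higher number from compound 2 to compound 4 (1.36 log units; beyond the scatter), a larger step than the one between the two drawn configurations. Isopropyl alone therefore does not account for the low number of compound 1, since hydrogen in place of methyl on the saturated chain carbon gives a 6.3-fold higher number from compound 1 to compound 4 (0.80 log units; beyond the scatter). No available evidence explains either step.

Going by these compounds, whether cyclobutyl or cyclohexyl on this nitrogen would match cyclopentyl remains open. So does whether the longer chain of compound 1 would lower the number further alongside cyclopentyl.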